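A New Substituent Beyond Bromo and Cyano

A few compounds are considered here, and "the series" means these few. Any claim that something is new, unique, unknown or untested is made for them only; others in the source may bear on it.

Among the compounds with values here, compound 3 `N#Cc1ccc(S(=O)(=O)NNc2ccc(Br)cc2)cc1` gives 176 nM in an assay for inhibition of Indoleamine 2,3-dioxygenase 1 (Homo sapiens), read by spectrophotometry, with stated times of 1 h and 4 h (on this read-out lower numbers stand for stronger inhibition and higher numbers for weaker inhibition), the highest of the three numbers measured so far, although compound 1 `O=S(=O)(NNc1ccc(Br)cc1)c1ccccc1` with 172 nM lies within the scatter of it. Compound 2 `O=S(=O)(NNc1ccc(Br)cc1)c1ccc(Br)cc1` gives 85 nM in this assay. Adding bromo brought a 2.0-fold lower number from compound 1 to compound 2 (0.31 log units; beyond the scatter), adding cyano brought a 1.0-fold higher number from compound 1 to compound 3 (0.01 log units; within the scatter), and exchanging bromo for cyano brought a 2.1-fold higher number from compound 2 to compound 3 (0.32 log units; beyond the scatter). Compound 4 `COC(=O)CCc1ccc(S(=O)(=O)NNc2ccc(Br)cc2)cc1` carries 2-(methoxycarbonyl)ethyl in place of cyano on an aromatic carbon. Within the data shown here, none of the measured steps covers a chain of this kind, and the substituent changes seen so far were modest or within the scatter. Compound 4 is therefore expected to show a 1.0-fold lower number from compound 3 to compound 4 (0.02 log units; within the scatter), little beyond the scatter. The estimated value of compound 4 in this assay is 170 nM, with a range from 60 nM to 500 nM.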

Compound 4, half-maximal inhibitory concentration: 121 nM
Beside the measured number, compound 4's estimate is 1.4-fold (0.15 log units) above it; the measured number falls inside the stated range.
By their numbers in this assay, from the lowest: compounds 2, 4, 1 and 3 (each within the scatter of the next, the first and the last beyond it).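

Compound 4 shows that this position, on an aromatic carbon para to a large group, takes the 2-(methoxycarbonyl)ethyl chain in this assay with no change beyond the scatter: a 1.5-fold lower number from compound 3 to compound 4 (0.16 log units; within the scatter), a 1.4-fold lower number from compound 1 to compound 4 (0.15 log units; within the scatter) and a 1.4-fold higher number from compound 2 to compound 4 (0.15 log units; within the scatter). The chain thus cannot be told apart from hydrogen, bromo or cyano here, although bromo and cyano can be told apart from each other. Nothing available explains this result. From the compounds shown here alone, whether a carboxylic acid in place of the ester, a longer chain or an amine at this position would give a step beyond the scatter remains open.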